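Two Inactive Amides and a Rearranged Isomer

The source may report more compounds than this note shows. Statements on the series, on what has been measured and on what is new or still open speak of the compounds shown alone.

Compound 1 `O=C(Nc1ccccc1)c1cccc(Br)c1` and compound 2 `COc1ccc(Br)cc1C(=O)Nc1ccc(Sc2nc3ccccc3s2)cc1` were both examined in an assay on isolated protein for inhibition of thiosulfate sulfurtransferase (Homo sapiens), with a stated time of 60 min, in the absence of a further agent; on this read-out higher numbers stand for weaker inhibition and lower numbers for stronger inhibition. For compound 1 the measurement returned only the limit > 100000 nM. For compound 2 the measurement likewise returned only the limit > 100000 nM. Among the compounds with values here, compound 2 thus stands at the edge of what this assay resolves, since the only evidence available is the limit of > 100000 nM in this assay, at which 2 of the 2 values shown sit, and no numerical ordering between the two measured compounds can be drawn from it.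

Compound 3 `COc1c(Br)cccc1C(=O)Nc1ccc(Sc2nc3ccccc3s2)cc1` has not yet been measured. It differs from compound 2 by a group of 9 heavy atoms (7 carbon, 1 oxygen, 1 bromine; one six-membered aromatic ring of carbon only) in place of a group of 9 heavy atoms (7 carbon, 1 oxygen, 1 bromine; one six-membered aromatic ring of carbon only), on a carbonyl carbon. Within the data shown here, no step between two measured compounds is available, so there is no precedent for how this rearrangement affects inhibition in this assay. Because compound 2 itself gave only the limit > 100000 nM, the expected step is a number no higher from compound 2 to compound 3 (the limit leaves the size open), which amounts to no change beyond the scatter. Compound 3 is accordingly estimated at 100000 nM, with a range from 30000 nM to 300000 nM, and the most likely outcome is that this assay again reports only a limit rather than a number.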

Compound 3, half-maximal inhibitory concentration: > 100000 nM
Compound 3: no number, only a limit (the forecaster's own chance of this, stated with the estimate: 80%); the middle value lies on the limit itself.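

Compound 2 and compound 3 both end at a limit rather than a number in this assay, so the step between these two isomers cannot be read: the limit of > 100000 nM in this assay, at which 3 of the 3 values shown sit.

The compounds shown leave open whether any of these amides would give a number in this assay, and whether the 5-bromo-2-methoxyphenyl group and its rearranged isomer differ at all.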